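A few compounds are considered here, and "the series" means these few. Any claim that something is new, unique, unknown or untested is made for them only; others in the source may bear on it.

Three compounds built on the shared core of compound 1 `CCCCCCCCCCS(=O)(=O)/C=C/c1ccc(O)c(O)c1` have been measured in a functional assay, read by fluorescence and spectrophotometry, with a stated time of 1 h; on this read-out higher numbers stand for an effect only at larger amounts of compound and lower numbers for an effect already at smaller amounts. Compound 1 gives 6800 nM. Compound 2 `O=S(=O)(/C=C/c1ccc(O)c(O)c1)CC1CCC1` gives 8800 nM, and compound 3 `O=S(=O)(/C=C/c1ccc(O)c(O)c1)CC1CCCN1` gives 13800 nM. Compound 3 thus sits at the upper end of the three values: its gap to compound 1 lies beyond the scatter, whereas its gap to compound 2 does not. Among the compounds with values here, the only single-point step available is a 1.6-fold higher number from compound 2 to compound 3 (0.20 log units; within the scatter), which is within the scatter. Compound 4 `O=S(=O)(/C=C/c1ccc(O)c(O)c1)CC1CCCCC1` differs from compound 3 by cyclohexyl in place of pyrrolidin-2-yl on a saturated chain carbon bound to a sulfonyl sulfur. Compound 4 thereby carries a ring of carbon only, as compound 2 does. Because a 1.6-fold higher number from compound 2 to compound 3 (0.20 log units; within the scatter) stayed within the scatter, no step beyond the scatter is expected for the present change either; if anything, a slightly lower number is expected, toward the values of compound 2 and compound 1. The step expected from this change is a 1.7-fold lower number from compound 3 to compound 4 (0.24 log units; within the scatter). Compound 4 is therefore estimated at 8000 nM, with a range from 3500 nM to 18000 nM.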

Compound 4, half-maximal effective concentration: 7500 nM
For compound 4 the middle estimate is 1.1-fold (0.03 log units) above the measured one; low and high end bracket the measured number.
By their numbers in this assay, from the lowest: compounds 1, 4, 2 and 3 (each within the scatter of the next, the first and the last beyond it).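

In this assay, within the data shown here, cyclohexyl in place of pyrrolidin-2-yl on a saturated chain carbon bound to a sulfonyl sulfur gives a 1.8-fold lower number from compound 3 to compound 4 (0.26 log units; within the scatter) and so stays close to the earlier compounds, even though the change removes the ring nitrogen and enlarges the ring. Cyclohexyl in place of cyclobutyl at the same place gives a 1.2-fold lower number from compound 2 to compound 4 (0.07 log units; within the scatter) and shows that, between these two carbon-only rings, ring size moves the number by no more than the scatter. No independent evidence is available to explain these results.

The step from compound 3 to compound 4 changes the ring size and removes the nitrogen together, so a piperidin-2-yl group would be needed to tell the two changes apart. On these data alone, it also remains open whether a phenyl ring or a carboxylic acid at this place would give a step beyond the scatter.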